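Swapping chloro for methyl on the aryl ring of compound 3

This account rests on a few compounds, and the source may have more. Where it says the series, first, only, none or still open, it means among the compounds named here.

Three thiocarbamate amides sharing one core have been tested in an ADME assay on MT4 cells (Homo sapiens) for cytotoxicity, read by MTT assay; on this read-out lower numbers stand for higher toxicity in this test and higher numbers for lower toxicity in this test. Compound 1 `O=C1c2ccccc2C(=O)N1CCOC(=S)N(C(=O)c1ccc(C(F)(F)F)cc1)c1ccc(Cl)cc1` gives 10000 nM. Compound 2 `O=C1c2ccccc2C(=O)N1CCOC(=S)N(C(=O)c1cccc(F)c1F)c1ccc(Cl)cc1` gives 58000 nM. Compound 3 `Cc1cc(C(=O)N(C(=S)OCCN2C(=O)c3ccccc3C2=O)c2ccc(Cl)cc2)ccc1Br` gives 18000 nM, the second highest of the three numbers; its nearest neighbour is compound 1, with a 1.8-fold higher number from compound 1 to compound 3 (0.26 log units; within the scatter) lying within the scatter, while its furthest is compound 2, with a 3.2-fold lower number from compound 2 to compound 3 (0.51 log units; beyond the scatter) lying beyond it. The other measured step is a 5.8-fold higher number from compound 1 to compound 2 (0.76 log units; beyond the scatter).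

Compound 4 `Cc1ccc(N(C(=O)c2ccc(Br)c(C)c2)C(=S)OCCN2C(=O)c3ccccc3C2=O)cc1` has not yet been tested. It differs from compound 3 by methyl in place of chloro on an aromatic carbon; read one bond further out, 4-chlorophenyl becomes 4-methylphenyl. Among the measured compounds shown here, every measured step instead changes the group on a carbonyl carbon, so none of them bears directly on this change, and the data give no step at the aromatic carbon in question. With nothing pointing in either direction, no step beyond the scatter is expected in this assay from compound 3 to compound 4. Compound 4 is therefore estimated to give 18000 nM in this assay, within a range of 7000 nM to 45000 nM, which means an expected step of no change at the digits printed from compound 3 to compound 4 (within the scatter).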

Compound 4, half-maximal cytotoxic concentration: > 100000 nM
Compound 4: only a limit was reported; the forecaster's own chance of this, stated with the estimate: 20%; at least 5.5-fold (0.74 log units) between middle value and limit.
By their numbers in this assay, from the lowest: compounds 1 and 3 (each within the scatter of the next); then compound 2. At a limit, above all of these: compound 4.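

In this assay, among the compounds shown here, the earlier compounds all carried 4-chlorophenyl and differed only in the group on a carbonyl carbon, so this pair gives the first reading at this aromatic carbon: going from 4-chlorophenyl to 4-methylphenyl gives an at least 5.5-fold higher number from compound 3 to compound 4 (0.74 log units; beyond the scatter). The value of compound 4 is a limit of the assay and not a number: the limit of > 100000 nM in this assay, at which 1 of the 4 values shown sits. This aromatic carbon is therefore not a silent position: one heavy atom exchanged for one heavy atom, with no hydrogen-bond donor, acceptor or net charge entering or leaving, takes the number beyond the scatter, and compound 4 stands above all the other compounds shown.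

The compounds shown do not tell why the number moves, how far compound 4 lies past its limit, or whether the same exchange would carry the same weight with the 2,3-difluorophenyl of compound 2 on the carbonyl carbon. They also leave open what a methoxy group, an ethyl group or an amine would do on this aromatic carbon, and so whether the step follows the arrival of methyl or the departure of chloro.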